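Cyclohexyl for benzyl on the urea nitrogen

The compounds below may be only part of what the source reports. "The series", "measured", "known", "first", "only" and "open" are said of these compounds alone.

Of the compounds shown here, three sharing one core have been measured in a functional assay on A549 cells (Homo sapiens) for antiproliferative activity, read by MTT assay, with a stated time of 48 h; a higher number here means a weaker inhibitor, a lower number a stronger inhibitor. Compound 1 `O=C(Nc1ccccc1)Nc1cccc(NC(=O)c2ccccn2)c1` gives 5190 nM. Compound 2 `Cc1ccc(NC(=O)Nc2cccc(NC(=O)c3ccccn3)c2)cc1` gives 20 nM. Compound 3 `O=C(NCc1ccccc1)Nc1cccc(NC(=O)c2ccccn2)c1` gives 2990 nM, the second highest of the three numbers: it sits nearest compound 1, as a 1.7-fold lower number from compound 1 to compound 3 (0.24 log units; within the scatter) shows, and furthest from compound 2, as a 150-fold higher number from compound 2 to compound 3 (2.17 log units; beyond the scatter) shows.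

Compound 4 `O=C(Nc1cccc(NC(=O)c2ccccn2)c1)NC1CCCCC1` differs from compound 3 in one place: cyclohexyl in place of benzyl on an amide-type nitrogen. Going by the values given here, no measured step replaces an aromatic ring on that nitrogen with a non-aromatic one, so the closest guide is indirect. The step of a 1.7-fold lower number from compound 1 to compound 3 (0.24 log units; within the scatter) was within the scatter, while a 150-fold higher number from compound 2 to compound 3 (2.17 log units; beyond the scatter) was large, so what stands on this nitrogen can matter greatly or hardly at all. With nothing pointing to a gain like that of compound 2, the expected step of a 1.0-fold higher number from compound 3 to compound 4 (0.00 log units; within the scatter) in this assay is none beyond the scatter. Compound 4 is therefore estimated at 3000 nM, with a range from 700 nM to 13000 nM.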

Compound 4, half-maximal inhibitory concentration: 6260 nM
Beside the measured number, compound 4's estimate is 2.1-fold (0.32 log units) below it; measured number inside the range.
By their numbers in this assay, from the lowest: compound 2; then compounds 3, 1 and 4 (each within the scatter of the next, the first and the last beyond it).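

In this assay a non-aromatic ring on this amide-type nitrogen gives a 2.1-fold higher number from compound 3 to compound 4 (0.32 log units; beyond the scatter) as a modest step, while a 1.2-fold higher number from compound 1 to compound 4 (0.08 log units; within the scatter) leaves cyclohexyl and phenyl indistinguishable. An aromatic ring on this nitrogen therefore does not by itself set the number among these compounds, since phenyl and cyclohexyl cannot be told apart here. Only the 4-methylphenyl of compound 2 stands apart, as a 310-fold higher number from compound 2 to compound 4 (2.50 log units; beyond the scatter) shows in the other direction from the rest of the set. No measurement offered here accounts for these steps.

Still open, going by these compounds, is whether the low number of compound 2 is specific to methyl, or whether an ethyl group, a methoxy group or a chlorine atom in its place on the phenyl ring would match it. Equally open, on these data alone, is whether a 4-methylcyclohexyl group would bring the same gain to compound 4 that methyl brought to compound 1.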